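The source may hold more compounds than are shown below. What is called first, only, known or untested is meant among the compounds shown, and "the series" means these compounds.

Compound 3 `O=C(CN1CCN(c2ccc(Cl)cc2)CC1)N1CCN(c2nnc(-c3ccc(Cl)cc3)c(-c3ccc(Cl)cc3)n2)CC1` carries a 4-chlorophenyl on an amine nitrogen in a ring of the shared core. In an ADME assay on NIH3T3 cells (Mus musculus) for cytotoxicity, read by MTT assay, with a stated time of 24 h (on this read-out higher numbers stand for weaker inhibition and lower numbers for stronger inhibition), compound 3 returns only a limit, > 803000 nM. Compound 1 `COc1ccccc1N1CCN(CC(=O)N2CCN(c3nnc(-c4ccc(Cl)cc4)c(-c4ccc(Cl)cc4)n3)CC2)CC1` gives 405000 nM in this assay. Compound 2 `COc1ccc(N2CCN(CC(=O)N3CCN(c4nnc(-c5ccc(Cl)cc5)c(-c5ccc(Cl)cc5)n4)CC3)CC2)cc1` likewise gives only a limit in this assay, > 809000 nM. The steps into compound 3 read an at least 1.9-fold higher number from compound 1 to compound 3 (0.29 log units; that floor lies within the scatter) and a step that the two limits leave unreadable from compound 2 to compound 3, and the step of an at least 1.9-fold higher number from compound 1 to compound 2 (0.30 log units; that floor lies within the scatter) shares the same floor; none of them resolves a difference beyond the scatter, so compound 3 stands where the series is read only as a limit (the limit of > 803000 nM in this assay, at which 1 of the 3 values shown sits).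

Compound 4 `O=C(CN1CCN(c2ccc([N+](=O)[O-])cc2)CC1)N1CCN(c2nnc(-c3ccc(Cl)cc3)c(-c3ccc(Cl)cc3)n2)CC1` differs from compound 3 by nitro in place of chloro on an aromatic carbon. Among the measured compounds shown here, no measured step alters that aromatic carbon in this way; the steps of an at least 1.9-fold higher number from compound 1 to compound 3 (0.29 log units; that floor lies within the scatter) and a step that the two limits leave unreadable from compound 2 to compound 3 show that exchanging the aryl group on that nitrogen moved the reading no further than the scatter, ending at a limit. Compound 4 is therefore expected to sit close to the limit as well, the expected step being an at least 1.1-fold lower number from compound 3 to compound 4 (0.05 log units; that floor lies within the scatter). Compound 4 is estimated at 700000 nM in this assay, between 300000 nM and 1000000 nM, with a fair chance that only a limit is reported.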

Compound 4, half-maximal inhibitory concentration: > 789000 nM
Compound 4 ended at the assay's limit (the forecaster's own chance of this, stated with the estimate: 55%); middle value at least 1.1-fold (0.05 log units) away from the limit.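

Compound 4 also reads only as a limit in this assay: the limit of > 789000 nM in this assay, at which 1 of the 4 values shown sits. Nitro, with its 3 heavy atoms and 2 hydrogen-bond acceptors, is the third group on this aromatic carbon after methoxy in compound 2 and chloro in compound 3; all three compounds end as limits, and the steps among them cannot be read. Among the compounds shown here, the only readable step is an at least 1.9-fold higher number from compound 1 to compound 4 (0.28 log units; that floor lies within the scatter), so this exchange of the aryl group resolves no difference.

On these data alone, it remains open whether an amine or a carboxylic acid on this aromatic carbon would give a measurable value rather than another limit. With a numerical value only for compound 1, the compounds shown also leave open whether moving a group around the aryl ring changes the reading beyond the scatter.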